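The source may report more compounds than this note shows. Statements on the series, on what has been measured and on what is new or still open speak of the compounds shown alone.

Measured in a functional assay on HT-1080 cells (Homo sapiens) for cytotoxicity, read by MTT assay, with a stated time of 72 h; on this read-out higher numbers stand for weaker inhibition and lower numbers for stronger inhibition:
- compound 1 `COc1ccc(/C=C2\CCC/C(=C\c3cccc(OC)c3OC)C2=O)cc1`: 16300 nM
- compound 2 `COc1cccc(/C=C2\CCC/C(=C\c3cccc(O)c3)C2=O)c1OC`: 8500 nM
- compound 3 `COc1ccc(/C=C2\CCC/C(=C\c3cccc(OC)c3OC)C2=O)cc1OC`: 6400 nM

Compound 3 gives 6400 nM, a value within the scatter of compound 2 at 8500 nM. Compound 4 `COc1cccc(/C=C2\CCC/C(=C\c3cc(OC)c(OC)c(OC)c3)C2=O)c1OC` differs from compound 3 by a methoxy in place of hydrogen on an aromatic carbon, ortho to a methoxy group (methoxy in place of hydrogen on an aromatic carbon). Within the data shown here, the one measured step of this same kind is a 2.5-fold lower number from compound 1 to compound 3 (0.41 log units; beyond the scatter), a modest change beyond the scatter. The other step, a 1.9-fold lower number from compound 1 to compound 2 (0.28 log units; within the scatter), is a different change and within the scatter, so it offers little guidance. A single precedent is thin evidence, but a similar small drop is expected. The expected step is a 1.8-fold lower number from compound 3 to compound 4 (0.26 log units; within the scatter). In this assay, the estimate for compound 4 is 3500 nM, expected to fall between 1200 nM and 9000 nM.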

Compound 4, half-maximal inhibitory concentration: 2300 nM
The estimate for compound 4 lay 1.5-fold (0.18 log units) above the measured number; the range from low to high includes it.
By their numbers in this assay, from the lowest: compound 4; then compounds 3, 2 and 1 (each within the scatter of the next, the first and the last beyond it).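

In this assay a methoxy in place of hydrogen on this aromatic carbon, ortho to a methoxy group, gives a 2.8-fold lower number from compound 3 to compound 4 (0.44 log units; beyond the scatter) as its step. Read with a 2.5-fold lower number from compound 1 to compound 3 (0.41 log units; beyond the scatter) as the earlier step, this makes two modest drops from adding a methoxy to the same aromatic ring, so the first drop no longer stands alone. From the compounds shown here alone, whether an amine or a fluorine at this place would lower the number as well remains open. Nothing measured here says why the number falls.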